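A few compounds are considered here, and "the series" means these few. Any claim that something is new, unique, unknown or untested is made for them only; others in the source may bear on it.

Measured compounds:
- compound 1 `COc1ccccc1/C=C1\NS(=O)(=O)c2ccccc2C1=O` — 1240 nM
- compound 2 `O=C1/C(=C/c2ccccc2Br)NS(=O)(=O)c2ccccc21` — 7430 nM
- compound 3 `O=C1/C(=C/c2ccc(Cl)cc2)NS(=O)(=O)c2ccccc21` — 4350 nM

In an assay for inhibition of Intestinal-type alkaline phosphatase (Homo sapiens), read by spectrophotometry, with stated times of 10 min and 20 min (a lower number here means a stronger inhibitor, a higher number a weaker inhibitor), compound 3 gives 4350 nM, the second highest of the three numbers. Its nearest neighbour is compound 2, with a 1.7-fold lower number from compound 2 to compound 3 (0.23 log units; within the scatter), a gap within the scatter; the furthest is compound 1, which lies a good deal lower, beyond the scatter. Compound 4 `Cc1ccccc1/C=C1\NS(=O)(=O)c2ccccc2C1=O` has not yet been measured in this assay. It differs from compound 3 in one place: 2-methylphenyl in place of 4-chlorophenyl on a double-bonded chain carbon bound to a double-bonded ring carbon.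

Going by the values given here, two measured steps bear on this change. The swap of the whole aryl group, from compound 2 to compound 3, gave a 1.7-fold lower number from compound 2 to compound 3 (0.23 log units; within the scatter), within the scatter. The exchange of one group for another on the aromatic carbon, from compound 1 to compound 2, gave a 6.0-fold higher number from compound 1 to compound 2 (0.78 log units; beyond the scatter), a modest step beyond the scatter. Among the compounds with values here, the new 2-methylphenyl shares its ring with none of the three exactly, so the data give no direct precedent; a step in this assay of at most modest size, likely within the scatter, is expected, with a lean toward a lower number. Compound 4 is therefore estimated at 3000 nM, with a range from 1000 nM to 9000 nM. This means an expected step of a 1.5-fold lower number from compound 3 to compound 4 (0.16 log units; within the scatter).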

Compound 4, half-maximal inhibitory concentration: 3750 nM
Compound 4: the middle estimate sits 1.3-fold (0.10 log units) below what was measured; low and high end bracket the measured number.
By their numbers in this assay, from the lowest: compound 1; then compounds 4, 3 and 2 (each within the scatter of the next).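

In this assay, the exchange of 4-chlorophenyl for 2-methylphenyl on the double-bonded chain carbon gave a 1.2-fold lower number from compound 3 to compound 4 (0.06 log units; within the scatter), so this swap of the whole aryl group, like the earlier one from 2-bromophenyl to 4-chlorophenyl, does not move the result beyond the scatter. On the aromatic carbon itself, methyl in place of bromo gave a 2.0-fold lower number from compound 2 to compound 4 (0.30 log units; within the scatter), while methyl in place of methoxy gave a 3.0-fold higher number from compound 1 to compound 4 (0.48 log units; beyond the scatter), so among the three groups tried on that carbon, methoxy alone now stands apart from both of the others, and compound 1 is set off by two separate steps rather than one. No measurement offered here accounts for this difference.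

The 2-methylphenyl and 4-chlorophenyl groups differ in both substituent and ring location, so 2-chlorophenyl and 4-methylphenyl would be needed to separate the two changes. From the compounds shown here alone, it also remains open whether the standing of compound 1 belongs to methoxy alone or would extend to a hydroxyl, an ethoxy group, an amine or a carboxylic acid on the same aromatic carbon.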